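Para-Chloro for Fluoro on the Benzoyl of Compound 2

This account rests on a few compounds, and the source may have more. Where it says the series, first, only, none or still open, it means among the compounds named here.

The pair begins with compound 1 `O=C([C@H]1CC2CCC1C2)N1CC(c2nc(-c3cccc(F)c3)no2)C1`, which in an assay on HEK293 cells for positive allosteric modulation of metabotropic glutamate receptor 5 (Homo sapiens), read by FLIPR (a higher number here means that more compound is needed for the effect, a lower number that less compound is needed), gives 72 nM, and compound 2 `O=C(c1ccc(F)cc1)N1CC(c2nc(-c3cccc(F)c3)no2)C1`, which in this assay gives 2400 nM. Among the compounds with values here, the only measured step, a 33-fold higher number from compound 1 to compound 2 (1.52 log units; beyond the scatter), sits at the carbonyl and leaves compound 2 with the higher of the two numbers so far.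

Compound 3 `O=C(c1ccc(Cl)cc1)N1CC(c2nc(-c3cccc(F)c3)no2)C1` differs from compound 2 by chloro in place of fluoro on an aromatic carbon, on the aromatic ring that the step from compound 1 to compound 2 introduced. Within the data shown here, no measured step concerns an exchange of one halogen for another on that ring; the single step on record, from compound 1 to compound 2, swaps the whole group on the carbonyl and therefore gives no direct guide to the size of this change. With nothing to point one way or the other, the step from compound 2 to compound 3 in this assay is expected to stay within the scatter, a 1.3-fold lower number from compound 2 to compound 3 (0.10 log units; within the scatter).

Compound 3 is accordingly estimated at 1900 nM, within a range from 500 nM to 7000 nM.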

Compound 3, half-maximal effective concentration: 2500 nM
Beside the measured number, compound 3's estimate is 1.3-fold (0.12 log units) below it; low and high end bracket the measured number.
By their numbers in this assay, from the lowest: compound 1; then compounds 2 and 3 (each within the scatter of the next).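

In this assay, the change from 4-fluorophenyl to 4-chlorophenyl gives a 1.0-fold higher number from compound 2 to compound 3 (0.02 log units; within the scatter) and so leaves the number within the scatter: at this place, para to a large group, the two halogens cannot be told apart. The large gap to compound 1 also holds with either halogen, since a 35-fold higher number from compound 1 to compound 3 (1.54 log units; beyond the scatter) stands with the chloro and a 33-fold higher number from compound 1 to compound 2 (1.52 log units; beyond the scatter) with the fluoro, both beyond the scatter, and compound 1 keeps the lowest number of the three. No measurement at hand offers a reason for either observation.

The compounds shown cover only two halogens at this one place, so it remains open whether a methyl, a methoxy, a trifluoromethyl or a nitrile there would also leave the number unchanged, or whether a hydrogen in place of the halogen would do the same. From the compounds shown here alone, it also remains open which feature of the group on the carbonyl of compound 1 goes with its lower number, and a cyclohexyl or a cyclopentyl on that carbonyl would bear on this question.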